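The source may report more compounds than this note shows. Statements on the series, on what has been measured and on what is new or still open speak of the compounds shown alone.

Working notes on the series.

Compound 1 `CCN1CCc2c(sc(NC(=O)Nc3ccc(Cl)cc3)c2C(N)=O)C1` is the reference point. In a functional assay (strain AB) with Danio rerio as the target, read by microscopy, with a stated time of 1 h (on this read-out higher numbers stand for an effect only at larger amounts of compound and lower numbers for an effect already at smaller amounts), compound 1 gives 3120 nM; of the three measured compounds this is the second highest number, with compound 3 nearest and compound 2 furthest away. Compound 2 `NC(=O)c1c(NC(=O)Nc2ccc(Cl)cc2)sc2c1CCN(CCCNC(=O)CCc1cccnc1)C2` gives 470 nM in this assay, and the step of a 6.6-fold lower number from compound 1 to compound 2 (0.82 log units; beyond the scatter) is placed on the saturated ring chain, away from the urea. Compound 3 `CCN1CCc2c(sc(NC(=O)Nc3ccc(Cl)cc3)c2C(=O)NCCO)C1` gives 9400 nM, and the step of a 3.0-fold higher number from compound 1 to compound 3 (0.48 log units; beyond the scatter) sits on the carboxamide nitrogen, again away from the urea.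

Compound 4 `CCN1CCc2c(sc(NC(=O)c3ccccc3)c2C(N)=O)C1` differs from compound 1 as follows. phenyl in place of (4-chlorophenyl)amino on a carbonyl carbon

For the measured compounds named here, neither measured step touches the carbonyl carbon where this change sits, so no direct precedent for it exists in the set; both measured steps show only that changes at the periphery of the shared core move the number by modest amounts. Removal of the (4-chlorophenyl)amino group, with its one hydrogen-bond donor and its chlorine, for a bare phenyl is a larger change than either measured one, and the expectation is for a higher number. For compound 4 the step of a 3.8-fold higher number from compound 1 to compound 4 (0.59 log units; beyond the scatter) is expected, giving an estimate of 12000 nM with a range from 3000 nM to 50000 nM.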

Compound 4, half-maximal effective concentration: > 25000 nM
Compound 4: a limit, no number (the forecaster's own chance of this, stated with the estimate: 25%); middle value at least 2.0-fold (0.31 log units) away from the limit.
By their numbers in this assay, from the lowest: compound 2; then compound 1; then compound 3. At a limit, above all of these: compound 4.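

Compound 4 gives a limit and not a number in this assay: the limit of > 25000 nM in this assay, at which 1 of the 4 values shown sits. The step of an at least 8.0-fold higher number from compound 1 to compound 4 (0.90 log units; beyond the scatter) is the only one shown on the carbonyl carbon whose other neighbour is an amide-type nitrogen, and it gives this position its first direct reading: in this pair, phenyl in place of (4-chlorophenyl)amino goes with a higher number, so effects appear only at larger amounts of compound. Earlier steps were confined to the saturated chain and the amide-type nitrogen, whereas this one shows that the shared core alone, with phenyl on this carbonyl carbon, does not keep the number of compound 1 within the scatter.

The change removes the nitrogen and the chlorine together, so the compounds shown cannot tell which of them carries the difference; a phenylamino group or a 4-chlorophenyl group on this carbonyl carbon would separate the two. From the compounds shown here alone, the full size of the step also stays open, as does whether the lower number of compound 2 would carry over to a compound with phenyl at this place.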